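The source may report more compounds than this note shows. Statements on the series, on what has been measured and on what is new or still open speak of the compounds shown alone.

Measured in a functional assay on HCT-116 cells (Homo sapiens) for inhibition, read by MTT assay, with a stated time of 72 h; a higher number here means a weaker inhibitor of growth, a lower number a stronger inhibitor of growth:

- Compound 1 `O=C(O)/C=C/c1ccncc1-c1ccc2ccccc2c1`: > 30000 nM, a limit
- Compound 2 `COC1CN(C(=O)/C=C/c2ccncc2-c2ccc3ccccc3c2)C1`: > 30000 nM, a limit

Compound 2 thus stands only at a limit, > 30000 nM, and no number is known for it. The record so far is the limit of > 30000 nM in this assay, at which 2 of the 2 values shown sit. Compound 3 `O=C(/C=C/c1ccncc1-c1ccc2ccccc2c1)N1CCOCC1` changes one place, on a carbonyl carbon: morpholin-4-yl in place of 3-methoxyazetidin-1-yl on a carbonyl carbon. Among the compounds with values here, the only measured step bearing on this is a step that the two limits leave unreadable from compound 1 to compound 2, which offers no size to carry over. No step beyond the scatter is therefore expected in this assay, in either direction. Compound 3 is estimated at 30000 nM, with an expected range of 12000 nM to 60000 nM. The expected step is a number no higher from compound 2 to compound 3 (the limit leaves the size open).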

Compound 3, concentration for 50% growth inhibition: 6040 nM
Beside the measured number, compound 3's estimate is 5.0-fold (0.70 log units) above it, outside the stated range (below it).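

The carbonyl carbon proves to be a place where the attached group decides whether this assay gives a number at all, with morpholin-4-yl producing the first measurable growth inhibition here (an at least 4.9-fold lower number from compound 2 to compound 3 (0.69 log units; beyond the scatter)) and the same result against hydroxy (an at least 4.9-fold lower number from compound 1 to compound 3 (0.69 log units; beyond the scatter)). Compound 2 and compound 3 hold the same atoms, joined differently, so the amide link alone does not account for the gain. Compound 1 and compound 2 remain at a limit: the limit of > 30000 nM in this assay, at which 2 of the 3 values shown sit.

As far as these compounds go, the true size of both steps therefore stays open. So does whether piperazin-1-yl or an open-chain dimethylamino group on this carbonyl carbon would match morpholin-4-yl.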